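The source may report more compounds than this note shows. Statements on the series, on what has been measured and on what is new or still open speak of the compounds shown alone.

Working notes on the series. The shared core is carried by compound 1 `CC(C)CCn1nc(-c2cccs2)c(O)c(C2=NS(=O)(=O)c3cc(O)ccc3N2)c1=O`, compound 2 `CC(C)CCn1nc(-c2cccs2)c(O)c(C2=NS(=O)(=O)c3cc(OC(C)C(N)=O)ccc3N2)c1=O`, compound 3 `CC(C)CCn1nc(-c2cccs2)c(O)c(C2=NS(=O)(=O)c3cc(OC(C)(C)C(N)=O)ccc3N2)c1=O` and, not yet measured, compound 4 `CCC(Oc1ccc2c(c1)S(=O)(=O)N=C(c1c(O)c(-c3cccs3)nn(CCC(C)C)c1=O)N2)C(N)=O`. In an ADME assay on Huh-7 cells (Homo sapiens) for cytotoxicity, with a stated time of 72 h (a lower number here means that less compound is tolerated, a higher number that more compound is tolerated), compound 2 gives 68000 nM. Compound 1 gives > 25000 nM, which is a limit of the assay rather than a number. Compound 3 gives > 33000 nM, also a limit of the assay. On the numbers shown, compound 3 thus stands only at a limit, and only one of the three values is a plain number. The step that the limit leaves unreadable from compound 1 to compound 2 has no readable size; the limit of > 25000 nM in this assay, at which 1 of the 3 values shown sits, leaves it open. The same holds for a step that the two limits leave unreadable from compound 1 to compound 3, which sits between the limit of > 25000 nM in this assay, at which 1 of the 3 values shown sits, and (the limit of > 33000 nM in this assay, at which 1 of the 3 values shown sits), and for a step that the limit leaves unreadable from compound 2 to compound 3, left open by the limit of > 33000 nM in this assay, at which 1 of the 3 values shown sits.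

The change to compound 4 is 1-carbamoylpropyl in place of 1-carbamoyl-1-methylethyl on an oxygen on an aromatic ring. Of the measured steps only a step that the limit leaves unreadable from compound 2 to compound 3 touches the same group, and it is unreadable; no step shown is readable as a move beyond the scatter. The step that the limit leaves unreadable from compound 3 to compound 4 in this assay is therefore expected to stay within the scatter. Compound 4 is expected at 60000 nM, with a range of 25000 nM to 150000 nM, and a limit rather than a number is about as likely as not.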

Compound 4, half-maximal cytotoxic concentration: > 33000 nM
Compound 4: a limit, no number; the forecaster's own chance of this, stated with the estimate: 50%; the middle value lies beyond the limit too.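

In this assay compound 4 gives > 33000 nM, a limit of the assay and not a number, so its steps from compound 1, compound 2 and compound 3 cannot be read. The compounds shown leave open whether 1-carbamoylpropyl and 1-carbamoyl-1-methylethyl on an oxygen on an aromatic ring differ at all in this assay.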